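The source may hold more compounds than are shown below. What is called first, only, known or untested is meant among the compounds shown, and "the series" means these compounds.

Measured in a toxicity assay on THP-1 cells (Homo sapiens) for inhibition; a lower number here means that less compound is tolerated, a higher number that more compound is tolerated:
compound 1 `COc1ccc(-c2cnc(NC(=O)c3cccnc3)n2C)cc1`: > 100000 nM (a limit)
compound 2 `COc1ccc(-c2cnc(NC(=O)c3ccc(O)cc3)n2C)cc1`: > 100000 nM (a limit)
compound 3 `COc1ccc(-c2cnc(NC(=O)c3ccc(F)cc3)n2C)cc1`: >= 50000 nM (a limit)

Compound 3 has no number in this assay. It stands at the limit of >= 50000 nM in this assay, at which 1 of the 3 values shown sits. Compounds 1 and 2 also give no number, and they stand at the limit of > 100000 nM in this assay, at which 2 of the 3 values shown sit.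

Compound 4 `COc1ccc(-c2cnc(NC(=O)c3cccc(OC)c3)n2C)cc1` carries 3-methoxyphenyl in place of the 4-fluorophenyl of compound 3, on a carbonyl carbon whose other neighbours are: amide-type nitrogen. The counted difference is 3-methoxyphenyl in place of 4-fluorophenyl on a carbonyl carbon.

Going by the values given here, three measured steps bear on this place: a step that the two limits leave unreadable from compound 1 to compound 2, a step that the two limits leave unreadable from compound 1 to compound 3 and a step that the two limits leave unreadable from compound 2 to compound 3. None of them gives a size, so the series offers no measured shift to carry over. All three exchanges at this place end at a limit, and no number has yet appeared in this assay.

No step beyond the scatter is therefore expected, and no direction is expected either. The expectation rests on compound 3, whose limit is >= 50000 nM. The expected step is a step that the limit leaves unreadable from compound 3 to compound 4. Compound 4 is likely to be reported as a limit too. For compound 4 the estimated value is 80000 nM, with an expected range from 35000 nM to 150000 nM.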

Compound 4, half-maximal cytotoxic concentration: > 100000 nM
Compound 4: only a limit was reported (the forecaster's own chance of this, stated with the estimate: 85%); middle value at least 1.2-fold (0.09 log units) away from the limit.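

In this assay compound 4 gives > 100000 nM, which is a limit. The steps to compound 4 from compound 1, compound 2 and compound 3 cannot be read, as each pair ends in two limits. The compounds shown leave open whether any exchange on this carbonyl carbon changes the tolerated concentration at all.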